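The compounds below may be only part of what the source reports. "The series", "measured", "known", "first", "only" and "open" are said of these compounds alone.

Measured compounds in an assay on microsomes for inhibition of Amine oxidase [flavin-containing] A (Homo sapiens), read by fluorescence and spectrophotometry, with a stated time of 20 min; a higher number here means a weaker inhibitor, a lower number a stronger inhibitor:
Compound 1 `O=c1ccoc2ccc(OCc3cccc(Cl)c3)cc12` gives 424 nM.
Compound 2 `O=c1ccoc2ccc(OCc3ccc(Br)cc3)cc12` gives 95 nM.
Compound 3 `Cc1ccc(COc2ccc3occc(=O)c3c2)cc1` gives 3490 nM.

Compound 3 holds the highest number of the three in this assay; its nearest neighbour is compound 1, and compound 2 lies furthest from it. Among the measured compounds shown here, the single change that leads away from compound 3 gives compound 4 `O=c1ccoc2ccc(OCc3ccc(C(F)(F)F)cc3)cc12`: trifluoromethyl in place of methyl on an aromatic carbon, the place being an aromatic carbon of a six-membered aromatic ring of carbon only, para to a large group.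

For the measured compounds named here, one measured step bears on this: a 37-fold higher number from compound 2 to compound 3 (1.57 log units; beyond the scatter), a large step, which replaced a bromo at this same place with the methyl. Going by the values given here, no measured step replaces methyl with trifluoromethyl. The new group shares with bromo the absence of hydrogen and brings three fluorine atoms, so the expectation is a return toward a lower number, though not necessarily all the way to compound 2. The estimated step is a 5.0-fold lower number from compound 3 to compound 4 (0.70 log units; beyond the scatter). Compound 4 is expected at 700 nM, in the range 150 nM to 3000 nM.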

Compound 4, half-maximal inhibitory concentration: 879 nM
Estimate against measurement, compound 4: 1.3-fold (0.10 log units) below; the range from low to high includes it.
By their numbers in this assay, from the lowest: compound 2; then compound 1; then compound 4; then compound 3.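

In this assay, trifluoromethyl in place of methyl on this aromatic carbon gives a 4.0-fold lower number from compound 3 to compound 4 (0.60 log units; beyond the scatter) and so recovers part of what the methyl lost. Against bromo at the same place, the same group gives a 9.3-fold higher number from compound 2 to compound 4 (0.97 log units; beyond the scatter), which sets the three groups in a clear order at this position: bromo with the lowest number, then trifluoromethyl, then methyl. No measurement at hand accounts for this order.

Going by these compounds, whether iodo, chloro or methoxy at this place would fall below compound 2 or among the three groups remains open. Also open, on these data alone, is whether the order of bromo, trifluoromethyl and methyl would hold on another carbon of the same ring, or with a longer chain joining that ring to the shared core.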